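This account rests on a few compounds, and the source may have more. Where it says the series, first, only, none or still open, it means among the compounds named here.

Compound 2, with the structure `CCCCCCCCCCc1nc(N(C)C)c(C)c(C)c1O`, is the reference point here. Among the compounds with values here, in a functional assay on cells (Lymphocyte, Homo sapiens), read by trypan blue exclusion, with a stated time of 16 h, tested at 0.5 uM (on this read-out lower numbers stand for a weaker effect and higher numbers for a stronger effect at the one concentration tested), compound 2 gives 74%, the highest of the three numbers measured so far. Its nearest neighbour on this scale is compound 3, with the structure `CCCCCCCCCCCCCCCCCCCc1c(C)c(N(C)C)nc(C)c1O`, which in this assay gives 50%; furthest away is compound 1, with the structure `Cc1c(N(C)C)nc(CCCCCCCCCCO)c(O)c1C`, which gives 28%. Compound 1 and compound 2 differ in one place only, and the step of a number 46 percentage points higher from compound 1 to compound 2 (beyond the scatter) shows how much that single change moved the read-out.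

The next compound, compound 4, has the structure `CCCCCCCCCCCCCCCCCCCc1nc(N(C)C)c(C)c(C)c1O`. It differs from compound 2 in one place: nonyl in place of hydrogen on a saturated chain carbon, ten or more bonds along the chain from an aromatic carbon. Within the data shown here, no measured step isolates a change of this kind; the only one-place step available, from compound 1 to compound 2, concerns a different group. Compound 3 carries the longer chain as well, but it also differs from compound 2 elsewhere, so its lower number gives only a loose hint. The expectation is therefore a modest drop with wide uncertainty, a step of about a number 19 percentage points lower from compound 2 to compound 4 (beyond the scatter). For compound 4 the value in this assay is estimated at 55%, most likely between 30% and 80%.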

Compound 4, a percentage reported as activity, at one concentration (the size of the read-out at that concentration, not a potency): 38%
The estimate for compound 4 lay 17 percentage points above the measured number, and the stated range covers the measured number.
By their numbers in this assay, from the lowest: compounds 1 and 4 (each within the scatter of the next); then compound 3; then compound 2.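

Adding nonyl in place of hydrogen on a saturated chain carbon, ten or more bonds along the chain from an aromatic carbon, is the first change here that extends the chain rather than placing hydroxy on it, and in this assay it costs much of the effect, giving a number 36 percentage points lower from compound 2 to compound 4 (beyond the scatter). Two unlike groups at this place also cannot be told apart, since nonyl in place of hydroxy gives a number 10 percentage points higher from compound 1 to compound 4 (within the scatter), so among these three compounds the hydrogen of compound 2 at this place goes with the highest number, and neither replacement keeps it. No measurement shown here offers an explanation for this sensitivity to the chain.

Going by these compounds, it remains open how the read-out behaves for groups between these extremes, such as butyl or hexyl in place of hydrogen at this place, and so whether it falls gradually or abruptly as the chain grows. On these data alone, it is equally open whether an amine or a carboxylic acid in place of hydroxy at this place would read like hydroxy.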